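The compounds below may be only part of what the source reports. "The series", "measured", "known", "first", "only" and "open" are said of these compounds alone.

Measured so far in a functional assay on U-251 cells (Homo sapiens); on this read-out higher numbers stand for weaker inhibition of growth and lower numbers for stronger inhibition of growth:
- Compound 1 `O=S(=O)(/C=C/c1ccccc1)Cc1ccc(Nc2ncnc3ccccc23)cc1`: > 100000 nM
- Compound 2 `O=S(=O)(/C=C/c1ccc(Br)cc1)Cc1ccc(Nc2ncnc3ccccc23)cc1`: > 100000 nM

Compound 2 gives no exact number: > 100000 nM is a limit of the assay. Compound 1 also gives only a limit, > 100000 nM. The evidence so far comes down to the limit of > 100000 nM in this assay, at which 2 of the 2 values shown sit.

Compound 3 `O=S(=O)(/C=C/c1ccc(Cl)cc1Cl)Cc1ccc(Nc2ncnc3ccccc23)cc1` carries 2,4-dichlorophenyl in place of the 4-bromophenyl of compound 2, on a double-bonded chain carbon bound to a double-bonded chain carbon: 2,4-dichlorophenyl in place of 4-bromophenyl on a double-bonded chain carbon bound to a double-bonded chain carbon. For the measured compounds named here, the only measured step that bears on this change, bromo in place of hydrogen on an aromatic carbon, is a step that the two limits leave unreadable from compound 1 to compound 2. It offers no size to carry over, so no step beyond the usual scatter is expected in this assay, and another limit is the likeliest result. The expected change is a number no higher from compound 2 to compound 3 (the limit leaves the size open). For compound 3 the estimated value is 100000 nM, with an expected range from 20000 nM to 200000 nM.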

Compound 3, concentration for 50% growth inhibition: 4000 nM
Beside the measured number, compound 3's estimate is 25-fold (1.40 log units) above it, outside the stated range (below it).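

In this assay, the aromatic ring on the double-bonded chain carbon proves able to change the result: 2,4-dichlorophenyl in place of 4-bromophenyl gives an at least 25-fold lower number from compound 2 to compound 3 (1.39 log units; beyond the scatter), and 2,4-dichlorophenyl in place of phenyl gives an at least 25-fold lower number from compound 1 to compound 3 (1.39 log units; beyond the scatter). Going by these compounds, both steps start from a limit of the assay and not from a number, so their full size stays unknown. Before compound 3, nothing about this position could be read: the limit of > 100000 nM in this assay, at which 2 of the 3 values shown sit.

On these data alone, compound 3 changes the kind and the number of halogens in one step, so it stays open whether a single chlorine would do or both are needed. As far as these compounds go, how a methoxy group or an amine on this ring would fare in this assay also stays open.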